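The source may report more compounds than this note shows. Statements on the series, on what has been measured and on what is new or still open speak of the compounds shown alone.

Series notes, three compounds measured in a functional assay on the whole organism (Tail, strain ICR) with Mus musculus as the target, in the tail flick test, with a stated time of 60 min, at a dose of 25 umol/kg by the oral route; on this read-out higher numbers stand for a stronger effect at the one dose given and lower numbers for a weaker effect:

compound 1, `O=C(O)[C@@H]1CCCN1C(=O)CN(c1nc(Cl)nc2[nH]cnc12)C1CC1`, gives 34.9%
compound 2, `C[C@@H](O)[C@H](NC(=O)CN(c1nc(Cl)nc2[nH]cnc12)C1CC1)C(=O)O`, gives 30.1%
compound 3, `CC[C@H](C)[C@H](NC(=O)CN(c1nc(Cl)nc2[nH]cnc12)C1CC1)C(=O)OCc1ccccc1`, gives 40.6%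

Compound 2 holds the lowest of the three numbers. Its nearest neighbour is compound 1, which sits within the scatter of it; compound 3 lies beyond the scatter above it. Among the compounds with values here, the one single-point step measured, a number 4.8 percentage points lower from compound 1 to compound 2 (within the scatter), swaps the carboxylic-acid-bearing part attached to the carbonyl carbon and leaves the read-out essentially unchanged.

The next compound, compound 4, `O=C(O)CC[C@H](NC(=O)CN(c1nc(Cl)nc2[nH]cnc12)C1CC1)C(=O)O`, differs from compound 2 by 2-carboxyethyl in place of 1-hydroxyethyl on a saturated chain carbon bound to an amide-type nitrogen and a carbonyl carbon. Cut one bond further out, this reads as 1-carboxy-2-hydroxypropyl going to 1,3-dicarboxypropyl: again a swap of the acid-bearing part, with the shared core untouched. Within the data shown here, the only step that bears on it, a number 4.8 percentage points lower from compound 1 to compound 2 (within the scatter), stayed within the scatter, so a step of similar size is expected for a number 1.9 percentage points higher from compound 2 to compound 4 (within the scatter), with no direction beyond the scatter predicted. Compound 4 is therefore estimated at 32% in this assay, with a range from 20% to 45%.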

Compound 4, a percentage reported as activity, at one dose (the size of the read-out at that dose, not a potency): 33.3%
For compound 4 the middle estimate is 1.3 percentage points below the measured one; the range from low to high includes it.
By their numbers in this assay, from the lowest: compounds 2, 4, 1 and 3 (each within the scatter of the next, the first and the last beyond it).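

In this assay, 2-carboxyethyl in place of 1-hydroxyethyl on a saturated chain carbon bound to an amide-type nitrogen and a carbonyl carbon gives a number 3.2 percentage points higher from compound 2 to compound 4 (within the scatter). This position therefore accepts the loss of the hydroxyl group and the entry of a second carboxylic acid, on a longer chain, without the read-out leaving the scatter, which the earlier step, a change of the whole acid-bearing part, could not show for this carbon alone. Nothing measured here accounts for this outcome.

Still open, as far as these compounds go, is whether an amine at the end of this chain, or a carboxylic acid carried on a longer chain than 2-carboxyethyl, would move the number beyond the scatter. With a single dose and time point, the read-out also leaves open how these compounds compare in potency.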